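The source may hold more compounds than are shown below. What is called first, only, known or untested is meant among the compounds shown, and "the series" means these compounds.

Going by the values given here, compound 2, with the structure `COc1ccc(Cn2cc(COc3ccc4c(=O)ccoc4c3)nn2)cc1`, is the only member of this small set that returns a number rather than a limit in a functional assay on A549 cells (Homo sapiens) for cytotoxicity, read by MTT assay, with a stated time of 48 h (on this read-out higher numbers stand for weaker inhibition and lower numbers for stronger inhibition), where compound 2 gives 16500 nM. Its neighbour, compound 1, has the structure `O=c1ccoc2cc(OCc3cn(Cc4ccc(Cl)cc4)nn3)ccc12`. In this assay compound 1 reaches only a limit, > 100000 nM. Among the compounds with values here, the one measured step, methoxy in place of chloro on an aromatic carbon, gave an at least 6.0-fold lower number from compound 1 to compound 2 (0.78 log units; beyond the scatter), and it rests on (the limit of > 100000 nM in this assay, at which 1 of the 2 values shown sits), so its true size is not fixed. The unmeasured compound 3 has the structure `O=c1ccoc2cc(OCc3cn(Cc4ccc(Br)cc4)nn3)ccc12`, and it differs from compound 2 by bromo in place of methoxy on an aromatic carbon. This change runs in the opposite sense to the measured step, swapping the methoxy of compound 2 back for a halogen-bearing ring like that of compound 1. The expectation is therefore that the number in this assay rises, and compound 3 is expected to give 60000 nM, within a range from 20000 nM to 150000 nM. This estimate means a step of a 3.6-fold higher number from compound 2 to compound 3 (0.56 log units; beyond the scatter), with a real chance that compound 3, like compound 1, reports only a limit.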

Compound 3, half-maximal inhibitory concentration: > 100000 nM
Compound 3 ended at the assay's limit; the forecaster's own chance of this, stated with the estimate: 45%; middle value at least 1.6-fold (0.22 log units) away from the limit.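

The new step shows that the earlier contrast was not confined to chloro: in this assay, a second halogen on this aromatic carbon, para to a large group, also goes with a weaker result than methoxy, with an at least 6.0-fold higher number from compound 2 to compound 3 (0.78 log units; beyond the scatter). Among the three compounds, only compound 2, the one carrying methoxy, gives a number, 16500 nM. Both halogen-bearing compounds stop at a limit. The step from chloro to bromo cannot be read, because both of its values are limits of the assay: the limit of > 100000 nM in this assay, at which 2 of the 3 values shown sit.

The compounds shown leave open whether the lower number belongs to methoxy in particular or would also appear with another non-halogen group at this carbon, such as a hydroxyl, an amine or a longer ethoxy chain. They also leave open how far the true values of the chloro and bromo compounds lie beyond the limit, and whether the same order between methoxy and halogen would hold with the group elsewhere on the ring.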